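Sulfonyl in Place of Piperazine Hydrogen: Expected Jurkat Potency

The source may report more compounds than this note shows. Statements on the series, on what has been measured and on what is new or still open speak of the compounds shown alone.

Compound 1 `COC(=O)c1ccc(C2SCC(=O)N2c2ccc(N3CCN(Cc4cccc(C)c4)CC3)cn2)c(OC)c1` — in a functional assay on Jurkat cells (Homo sapiens) for antiproliferative activity, read by MTT assay and trypan blue exclusion, with a stated time of 72 h (on this read-out higher numbers stand for weaker inhibition and lower numbers for stronger inhibition), compound 1 sits at > 100000 nM, which is a limit of the assay and not a number.
Compound 2 `COC(=O)c1ccc(C2SCC(=O)N2c2ccc(N3CCN(Cc4cccc([N+](=O)[O-])c4)CC3)cn2)c(OC)c1` — in this assay compound 2 gives 37400 nM.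
Compound 3 `COC(=O)c1ccc(C2SCC(=O)N2c2ccc(N3CCNCC3)cn2)c(OC)c1` — in this assay compound 3 gives 19300 nM.

Compound 3 holds the lowest of the two numbers given; its nearest neighbour is compound 2, and the gap a 1.9-fold lower number from compound 2 to compound 3 (0.29 log units; within the scatter) lies within the scatter. Compound 1 stands only at the limit of > 100000 nM in this assay, at which 1 of the 3 values shown sits. Compound 4 `COC(=O)c1ccc(C2SCC(=O)N2c2ccc(N3CCN(S(=O)(=O)c4ccc(OC)cc4)CC3)cn2)c(OC)c1` differs from compound 3 in one place: (4-methoxyphenyl)sulfonyl in place of hydrogen on an amine nitrogen in a ring. For the measured compounds named here, two measured steps bear on this ring nitrogen. The step of an at least 5.1-fold lower number from compound 1 to compound 3 (0.71 log units; beyond the scatter) shows that taking the 3-methylbenzyl off the ring nitrogen lowered the number, and a 1.9-fold lower number from compound 2 to compound 3 (0.29 log units; within the scatter) points the same way but stays within the scatter. Putting a large group back onto that nitrogen is therefore expected to raise the number in this assay, though the group entering here is a (4-methoxyphenyl)sulfonyl rather than a benzyl, so the measured steps set its size only loosely. For compound 4 the expected step is a 2.3-fold higher number from compound 3 to compound 4 (0.37 log units; beyond the scatter). Compound 4 is estimated at 45000 nM, with a range from 15000 nM to 130000 nM, and with a fair chance that the assay returns only a limit.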

Compound 4, half-maximal inhibitory concentration: 45200 nM
Estimate against measurement, compound 4: 1.0-fold (0.00 log units) below; the range from low to high includes it.
By their numbers in this assay, from the lowest: compounds 3, 2 and 4 (each within the scatter of the next, the first and the last beyond it). At a limit, above all of these: compound 1.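

In this assay, for the compounds shown here, a 2.3-fold higher number from compound 3 to compound 4 (0.37 log units; beyond the scatter) is the first step from the free ring nitrogen to a substituted one that has real numbers at both ends and also lies beyond the scatter, and it shows that a group joined through a sulfonyl, not only a benzyl, goes with a higher number than hydrogen at this position. The (4-methoxyphenyl)sulfonyl and the 3-nitrobenzyl cannot be told apart here, with a 1.2-fold higher number from compound 2 to compound 4 (0.08 log units; within the scatter), so at this level of potency the change of linking atom from a benzyl carbon to a sulfonyl shows no separate effect of its own. The 3-methylbenzyl alone stands apart, with an at least 2.2-fold lower number from compound 1 to compound 4 (0.34 log units; beyond the scatter), and that end of the step is a limit of the assay: the limit of > 100000 nM in this assay, at which 1 of the 4 values shown sits.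

The compounds shown leave open whether the methoxy on the aromatic ring matters, which a plain phenylsulfonyl or a small methanesulfonyl on the same nitrogen would test. They also leave open whether an acetyl or another amide on this ring nitrogen would keep the number as low as that of the unsubstituted compound 3.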